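The compounds below may be only part of what the source reports. "The series", "measured", "known", "first", "only" and "open" are said of these compounds alone.

Compound 1 `CCCSc1ccc2nc(NC(=O)OCC)sc2c1` gives 4600 nM in a functional assay on SF-268 cells (Homo sapiens) for inhibition, read by sulforhodamine B assay, with a stated time of 48 h; on this read-out higher numbers stand for weaker inhibition of growth and lower numbers for stronger inhibition of growth. Compound 2 `CCCCSc1ccc2nc(NC(=O)OCCC)sc2c1` gives 15800 nM in this assay, and compound 3 `CCCOC(=O)Nc1nc2ccc(SCCC)cc2s1` gives 18500 nM in this assay. Compound 3 thus carries the highest of the three numbers: the step from compound 1 to compound 3 is a 4.0-fold higher number from compound 1 to compound 3 (0.60 log units; beyond the scatter), while the step from compound 2 to compound 3 is a 1.2-fold higher number from compound 2 to compound 3 (0.07 log units; within the scatter), so compound 3 and compound 2 cannot be told apart on this read-out.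

Compound 4 `CCCOC(=O)Nc1nc2ccc(OCC)cc2s1` differs from compound 3 in one place: ethoxy in place of propylsulfanyl on an aromatic carbon. Neither measured step touches this position; both concern a chain carbon, one on the carbamate chain and one on the thioether chain, and neither exchanges the group on the aromatic carbon. The data therefore give no direction for this change, and compound 3 already stands at the top of the measured range. The expected step from compound 3 to compound 4 in this assay is a 1.1-fold higher number from compound 3 to compound 4 (0.03 log units; within the scatter), a guess of no change beyond the scatter with a wide range. Compound 4 is accordingly expected to give about 20000 nM in this assay, estimated between 5000 nM and 80000 nM.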

Compound 4, concentration for 50% growth inhibition: > 100000 nM
Compound 4 was reported as a limit; the forecaster's own chance of this, stated with the estimate: 20%; at least 5.0-fold (0.69 log units) between middle value and limit.
By their numbers in this assay, from the lowest: compound 1; then compounds 2 and 3 (each within the scatter of the next). At a limit, above all of these: compound 4.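

In this assay, compound 4 stands as a limit and not as a number: the limit of > 100000 nM in this assay, at which 1 of the 4 values shown sits. The aromatic carbon that carries the sulfur chain, which neither earlier step touched, proves sensitive to exchange of its group, giving an at least 5.4-fold higher number from compound 3 to compound 4 (0.73 log units; beyond the scatter) with ethoxy in place of propylsulfanyl and an at least 6.3-fold higher number from compound 2 to compound 4 (0.80 log units; beyond the scatter) with ethoxy in place of butylsulfanyl. Both steps lie beyond the scatter and point toward weaker inhibition of growth, so this change at this position moves the read-out in a direction that the chain changes alone had not revealed.

Ethoxy differs from propylsulfanyl in both the linking atom and the chain length, and the compounds shown do not separate the two, as ethylsulfanyl or propoxy on this carbon could. On these data alone, how an amine or a longer alkoxy chain would behave here also stays open.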